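Thiophene in place of fluorophenyl on a kinase-inhibitor core

The source may report more compounds than this note shows. Statements on the series, on what has been measured and on what is new or still open speak of the compounds shown alone.

Measured compounds:
- Compound 1 `CC1C(=O)N(C)c2cnc(Nc3ccc(S(N)(=O)=O)cc3)nc2N1C`: 313 nM
- Compound 2 `CCC1C(=O)N(C)c2cnc(Nc3ccc(S(N)(=O)=O)cc3)nc2N1C`: 479 nM
- Compound 3 `CN1C(=O)C(c2ccc(F)cc2)N(C)c2nc(Nc3ccc(S(N)(=O)=O)cc3)ncc21`: 1770 nM

All three were tested in an assay on Sf9 cells for inhibition of serine/threonine-protein kinase 4 (Homo sapiens), read by luminescence and ADP-Glo, with a stated time of 1 h, in the presence of a further agent that is not named here; a lower number here means a stronger inhibitor, a higher number a weaker inhibitor. Compound 3 gives the highest of the three numbers: a 5.7-fold higher number from compound 1 to compound 3 (0.75 log units; beyond the scatter) and a 3.7-fold higher number from compound 2 to compound 3 (0.57 log units; beyond the scatter) both lie beyond the scatter, so compound 3 is the weakest of the three measured compounds. Compound 1 and compound 2 differ from each other by a 1.5-fold higher number from compound 1 to compound 2 (0.18 log units; within the scatter), which lies within the scatter.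

Compound 4 `CN1C(=O)C(c2cccs2)N(C)c2nc(Nc3ccc(S(N)(=O)=O)cc3)ncc21` is not yet measured. It differs from compound 3 in one place: thiophen-2-yl in place of 4-fluorophenyl on a saturated ring carbon.

Going by the values given here, no measured step swaps one aromatic ring for another on this saturated ring carbon; the only steps at that position replace a methyl or ethyl with a 4-fluorophenyl, and both raised the number modestly. Since compound 4 keeps an aromatic ring there, its number is expected to stay close to that of compound 3 rather than return toward compound 1 or compound 2. The expected step is a 1.2-fold lower number from compound 3 to compound 4 (0.07 log units; within the scatter), which is within the scatter. Compound 4 is therefore estimated at 1500 nM, with a range from 600 nM to 3800 nM.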

Compound 4, half-maximal inhibitory concentration: 88 nM
For compound 4 the middle estimate is 17-fold (1.23 log units) above the measured one; measured number outside the range, below it.
By their numbers in this assay, from the lowest: compound 4; then compounds 1 and 2 (each within the scatter of the next); then compound 3.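

In this assay, the identity of the aromatic ring on this saturated ring carbon matters in its own right: thiophen-2-yl in place of 4-fluorophenyl gives a 20-fold lower number from compound 3 to compound 4 (1.30 log units; beyond the scatter) and shows that merely keeping an aromatic ring there does not settle the number. Compound 3 alone made an aromatic ring at this position look like a loss compared with a small alkyl group, but the thiophene reverses that direction, with a 5.4-fold lower number from compound 2 to compound 4 (0.74 log units; beyond the scatter) and a 3.6-fold lower number from compound 1 to compound 4 (0.55 log units; beyond the scatter) so that no general rule about aromatic rings here holds across compound 3 and compound 4. Nothing measured here gives a reason for this large difference between two aromatic rings.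

The swap changes several things at once, including ring size, the sulfur that enters and the fluorine that leaves, so the compounds shown cannot say which of these goes with the lower number. A plain phenyl group on this carbon would separate the fluorine from the ring, and a furan-2-yl group would test whether another five-membered aromatic ring behaves like thiophen-2-yl.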